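From 4-fluorophenyl to 4-methylphenyl: the expected step

A few compounds are considered here, and "the series" means these few. Any claim that something is new, unique, unknown or untested is made for them only; others in the source may bear on it.

In a functional assay on HCT-116 cells (Homo sapiens) for antiproliferative activity, read by MTT assay, with a stated time of 72 h (on this read-out lower numbers stand for stronger inhibition and higher numbers for weaker inhibition), compound 3 `COc1ccc(/C=C2\S/C(=N\c3ccc(F)cc3)N(C)C2=O)cc1` gives 13300 nM. Compound 1 `COc1ccc(/C=C2\S/C(=N\c3ccc(Cl)cc3)N(C)C2=O)cc1` gives 10400 nM. Fluoro in place of chloro reads a 1.3-fold higher number from compound 1 to compound 3 (0.11 log units; within the scatter), so these two stand level. Compound 2 `COc1ccc(/C=C2\S/C(=N\c3ccc(C(C)(C)C)cc3)N(C)C2=O)cc1` gives > 100000 nM, which is a limit of the assay and not a number.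

Compound 4 `COc1ccc(/C=C2\S/C(=N\c3ccc(C)cc3)N(C)C2=O)cc1` carries methyl in place of fluoro on an aromatic carbon. Methyl has no measured precedent at this place, so only the neighbouring swaps bear on it. The chloro and fluoro step above is one of them. Tert-butyl in place of chloro gives an at least 9.6-fold higher number from compound 1 to compound 2 (0.98 log units; beyond the scatter), and fluoro in place of tert-butyl gives an at least 7.5-fold lower number from compound 2 to compound 3 (0.87 log units; beyond the scatter). Both of these lie beyond the scatter, and both set tert-butyl apart from chloro and fluoro.

Compound 4 is expected to stay close to the chloro and fluoro pair, with some lean towards a higher number on the evidence of an at least 9.6-fold higher number from compound 1 to compound 2 (0.98 log units; beyond the scatter). The expected step is a 1.3-fold higher number from compound 3 to compound 4 (0.11 log units; within the scatter), which is estimated to stay within the scatter. As far as these compounds go, the range is kept wider on the upper side, since the behaviour of methyl here remains open. For compound 4 the estimated value in this assay is 17000 nM, with an expected range of 7000 nM to 50000 nM.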

Compound 4, half-maximal inhibitory concentration: > 100000 nM
Compound 4: only a limit was reported (the forecaster's own chance of this, stated with the estimate: 8%); at least 5.8-fold (0.76 log units) between middle value and limit.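

In this assay methyl in place of fluoro (an at least 7.5-fold higher number from compound 3 to compound 4 (0.87 log units; beyond the scatter)) and methyl in place of chloro (an at least 9.6-fold higher number from compound 1 to compound 4 (0.98 log units; beyond the scatter)) show that the separation seen earlier with tert-butyl is not particular to that group. Among the four compounds, the chloro and fluoro pair stands apart from the methyl and tert-butyl pair, and no compound shown goes against this split, so a change of one heavy atom on this aromatic carbon is enough to move the read-out beyond the scatter. Compound 4 gives > 100000 nM, which is a limit of the assay and not a number; the step from compound 2 to compound 4 cannot be read, because both compounds sit at the same limit: the limit of > 100000 nM in this assay, at which 2 of the 4 values shown sit.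

Whether any other group at this place stays level with chloro and fluoro remains open, with bromo, hydroxyl, an amine, a nitrile and a carboxylic acid all untested among the compounds shown here. As far as these compounds go, it also remains open how methyl and tert-butyl would rank against each other, and whether the same split holds when the methoxy group of the shared core is changed.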